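Fluoro to trifluoromethyl: a step no measurement covers yet

The source may report more compounds than this note shows. Statements on the series, on what has been measured and on what is new or still open speak of the compounds shown alone.

In a functional assay on MCF7 cells (Homo sapiens) for antiproliferative activity, read by MTT assay, with a stated time of 24 h (a higher number here means a weaker inhibitor, a lower number a stronger inhibitor), compound 1 (`O=S(=O)(c1ccc(Cl)cc1)n1c(-c2cn(-c3ccccc3)nc2-c2ccc(F)cc2)nc2ccccc21`) gives 4960 nM and compound 2 (`O=S(=O)(c1ccc(Br)cc1)n1c(-c2cn(-c3ccccc3)nc2-c2ccc(F)cc2)nc2ccccc21`) gives 2630 nM. These two values lie within the usual scatter of each other, and compound 2 therefore stands level with compound 1 on the numbers available. For the measured compounds named here, the single measured step, a 1.9-fold lower number from compound 1 to compound 2 (0.28 log units; within the scatter), swaps chloro for bromo on an aromatic carbon.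

Compound 3 (`O=S(=O)(c1ccc(Br)cc1)n1c(-c2cn(-c3ccccc3)nc2-c2ccc(C(F)(F)F)cc2)nc2ccccc21`) differs from compound 2 in one place: trifluoromethyl in place of fluoro on an aromatic carbon. Here trifluoromethyl stands in place of fluoro on an aromatic carbon, para to a large group. Going by the values given here, the measured step concerns a different place in the molecule, and no measured pair shows this change. It offers only weak guidance, and no shift beyond the scatter is expected in either direction.

The estimated change is a 1.1-fold lower number from compound 2 to compound 3 (0.02 log units; within the scatter). For compound 3, the expected value is 2500 nM, with an estimated range of 900 nM to 7000 nM.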

Compound 3, half-maximal inhibitory concentration: 2470 nM
For compound 3 the middle estimate is 1.0-fold (0.01 log units) above the measured one; low and high end bracket the measured number.
By their numbers in this assay, from the lowest: compounds 3, 2 and 1 (each within the scatter of the next).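

In this assay, the step from fluoro to trifluoromethyl on the 4-substituted phenyl ring is a 1.1-fold lower number from compound 2 to compound 3 (0.03 log units; within the scatter). For the compounds shown here, the earlier step, chloro to bromo, concerned a different place in the molecule, so this is the first reading at this position: going from 1 heavy atom to 4 heavy atoms here leaves the two numbers indistinguishable. No measurement shown offers an explanation for this result.

Going by these compounds, both groups tested at this position contain fluorine, so it remains open whether an amine or a carboxylic acid on the same aromatic carbon would give a number beyond the scatter. On these data alone, it is also open whether the fluoro to trifluoromethyl step would read the same in the chloro series of compound 1.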